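The source may report more compounds than this note shows. Statements on the series, on what has been measured and on what is new or still open speak of the compounds shown alone.

In an assay on cells (strain Sprague-Dawley) for inhibition of Polyunsaturated fatty acid 5-lipoxygenase (Rattus norvegicus), with a stated time of 30 min (on this read-out higher numbers stand for weaker inhibition and lower numbers for stronger inhibition), the three measured compounds read:
compound 1, `CC(=O)Oc1ccc(/C=C/C(=O)OCCSc2nc(-c3ccc(S(C)(=O)=O)cc3)n(-c3ccccc3)n2)cc1OC(C)=O`, gives 1210 nM
compound 2, `CC(=O)Oc1ccc(/C=C/C(=O)OCCSc2nc(-c3ccc(S(C)(=O)=O)cc3)n(-c3ccc(C(F)(F)F)cc3)n2)cc1OC(C)=O`, gives 1060 nM
compound 3, `CC(=O)Oc1ccc(/C=C/C(=O)OCCCSc2nc(-c3ccc(S(C)(=O)=O)cc3)n(-c3ccc(Br)cc3)n2)cc1OC(C)=O`, gives 990 nM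

Compound 2 holds the second highest of these three numbers, yet both compound 3 and compound 1 lie within the scatter of it, so the three cannot be told apart. Compound 4, `COc1cc(/C=C/C(=O)OCCSc2nc(-c3ccc(S(C)(=O)=O)cc3)n(-c3ccc(C(F)(F)F)cc3)n2)ccc1OC(C)=O`, differs from compound 2 in one place: methyl in place of acetyl on an oxygen on an aromatic ring. Among the compounds with values here, the only measured step, a 1.1-fold lower number from compound 1 to compound 2 (0.06 log units; within the scatter), touches a different part of the molecule and says nothing about this oxygen. Within the data shown here, no measured pair informs the change, so the step from compound 2 to compound 4 is expected to stay within the scatter, a 1.1-fold lower number from compound 2 to compound 4 (0.03 log units; within the scatter). Compound 4 is therefore estimated at 1000 nM, in a range from 400 nM to 2500 nM.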

Compound 4, half-maximal inhibitory concentration: 920 nM
For compound 4 the middle estimate is 1.1-fold (0.04 log units) above the measured one; the range from low to high includes it.
By their numbers in this assay, from the lowest: compounds 4, 3, 2 and 1 (each within the scatter of the next).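

In this assay the exchange of acetoxy for methoxy gives a 1.2-fold lower number from compound 2 to compound 4 (0.06 log units; within the scatter) and leaves the two compounds indistinguishable. Within the data shown here, this is the first measured change at this oxygen, and it shows that the three heavy atoms of acetyl can give way to the single carbon of methyl with no readable effect on the result. No available evidence explains this outcome.

As far as these compounds go, whether a hydroxyl group or a longer chain such as propyl on this oxygen would also read alike remains open. So does whether the same exchange holds with other groups on the core.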